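Aryl triazole in place of sulfonamide on the core

The source may report more compounds than this note shows. Statements on the series, on what has been measured and on what is new or still open speak of the compounds shown alone.

Compound 1 `O=C1O[C@H]([C@@H](O)Cn2cc(CNS(=O)(=O)c3ccc(F)cc3)nn2)C(OCc2ccccc2)=C1OCc1ccccc1`: 25000 nM
Compound 2 `O=C1O/C(=C\Cn2cc(-c3cccc(O)c3)nn2)C(OCc2ccccc2)=C1OCc1ccccc1`: 74800 nM
Compound 3 `O=C1O/C(=C\Cn2cc(-c3cc(C(F)(F)F)cc(C(F)(F)F)c3)nn2)C(OCc2ccccc2)=C1OCc1ccccc1`: limit > 100000 nM

Of the compounds shown here, three sharing the same core have been tested in a functional assay on HeLa cells (Homo sapiens) for antiproliferative activity, read by MTT assay, with a stated time of 72 h; a lower number here means a stronger inhibitor, a higher number a weaker inhibitor. Compound 1 gives 25000 nM, the lowest of the two plain numbers; compound 2 gives 74800 nM, a gap beyond the usual scatter. For compound 3 the result is a limit of the assay, > 100000 nM, not a number (the limit of > 100000 nM in this assay, at which 1 of the 3 values shown sits).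

Compound 4 `O=C1O[C@H]([C@@H](O)Cn2cc(-c3ccc(Br)cc3)nn2)C(OCc2ccccc2)=C1OCc1ccccc1` has not yet been measured in this assay. It differs from compound 1 in one place: 4-bromophenyl in place of (((4-fluorophenyl)sulfonyl)amino)methyl on an aromatic carbon. Going by the values given here, compounds 2 and 3 both carry an aryl group on the same triazole carbon and both sit high in this assay, though their linker to the core also differs from that of compound 1 and compound 4, so no single step separates them. Given that compound 2 gives 74800 nM and compound 1 gives 25000 nM, compound 4 is expected to be weaker than compound 1, with a step of a 2.4-fold higher number from compound 1 to compound 4 (0.38 log units; beyond the scatter). The estimate for compound 4 is 60000 nM, in the range 20000 nM to 200000 nM, with a fair chance that only a limit is reported.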

Compound 4, half-maximal inhibitory concentration: 3910 nM
For compound 4 the middle estimate is 15-fold (1.19 log units) above the measured one; the measured number lies below the stated range.
By their numbers in this assay, from the lowest: compound 4; then compound 1; then compound 2. At a limit, above all of these: compound 3.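

Swapping the whole sulfonamide arm for an aryl group directly on the ring carbon gives a 6.4-fold lower number from compound 1 to compound 4 (0.81 log units; beyond the scatter) in this assay. This shows that the (((4-fluorophenyl)sulfonyl)amino)methyl group, with its hydrogen-bond donor and acceptors, is not needed for activity at this position: the smaller 4-bromophenyl, which has neither, does better on the same core. Nothing measured here says why the number falls.

Going by these compounds, it remains open whether the bromine matters or the phenyl ring alone is enough; a plain phenyl, or an amine or a carboxylic acid in place of the bromine, would separate the two. On these data alone, it is also open whether 4-bromophenyl would give a similar step on the different linker carried by compound 2 and compound 3.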